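This account rests on a few compounds, and the source may have more. Where it says the series, first, only, none or still open, it means among the compounds named here.

Measured so far in a functional assay on PC-3 cells (Homo sapiens) for inhibition, read by MTT assay, with a stated time of 96 h (a lower number here means a stronger inhibitor of growth, a higher number a weaker inhibitor of growth), are three compounds.

- Compound 1 `CC(C)C(=O)SCCCCCCNC(=O)c1cc(-c2ccncc2)n[nH]1` gives 22400 nM here
- Compound 2 `CCCC(=O)SCCCCCCNC(=O)c1cc(-c2ccncc2)n[nH]1` gives 32100 nM here
- Compound 3 `CCCCCCCC/C=C\CCCCCCCC(=O)SCCCCCCNC(=O)c1cc(-c2ccncc2)n[nH]1` gives > 50000 nM which is a limit and not a number

Compound 2 stands level with compound 1. Swapping isopropyl for propyl gives a 1.4-fold higher number from compound 1 to compound 2 (0.16 log units; within the scatter) so these two values cannot be told apart.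

Compound 4 `CSCCCCCCNC(=O)c1cc(-c2ccncc2)n[nH]1` differs from compound 2 at the sulfur: methyl in place of propylcarbonyl on a sulfur. This is methyl in place of propylcarbonyl on a sulfur, so the carbonyl leaves. Among the compounds with values here, every measured compound keeps that carbonyl, so no measured step matches this change. The nearest guide is a 1.4-fold higher number from compound 1 to compound 2 (0.16 log units; within the scatter) and it only alters the group on the carbonyl carbon. Also relevant is the limit of > 50000 nM in this assay, at which 1 of the 3 values shown sits, in this series, so a result reported only as a limit would be no surprise.

A modest step towards a higher number is therefore expected, possibly no larger than the scatter. The estimated step is a 1.4-fold higher number from compound 2 to compound 4 (0.15 log units; within the scatter) in this assay here. Compound 4 is expected at about 45000 nM with an estimated range from 20000 nM to 90000 nM here.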

Compound 4, concentration for 50% growth inhibition: > 50000 nM
Compound 4 gave a limit, no number (the forecaster's own chance of this, stated with the estimate: 50%); middle value at least 1.1-fold (0.04 log units) away from the limit.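

Until now every measured compound carried a carbonyl on the sulfur, and only the group on that carbonyl changed, whereas compound 4 has a plain methyl on the sulfur; in this assay compound 4 gives > 50000 nM, which is a limit and not a number. Replacing propylcarbonyl with methyl gives an at least 1.5-fold higher number from compound 2 to compound 4 (0.19 log units; that floor lies within the scatter), and replacing isopropylcarbonyl with methyl gives an at least 2.2-fold higher number from compound 1 to compound 4 (0.34 log units; beyond the scatter), so only the second step clearly shows a loss of growth inhibition. The true size of both steps stays hidden, since only a floor can be read, and such limits are common in this series: the limit of > 50000 nM in this assay, at which 2 of the 4 values shown sit.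

Compound 4 loses the carbonyl and the carbon chain on it in one change, so the compounds shown do not separate the two. Going by these compounds, how a free thiol or a longer chain such as hexyl directly on the sulfur would behave remains open.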